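The source may report more compounds than this note shows. Statements on the series, on what has been measured and on what is new or still open speak of the compounds shown alone.

Compound 1 `COc1cc(N(CC2CC2)c2ccc(Cl)c(Cl)c2)cnc1C(=O)[C@H]1C[C@@H]1C(=O)O`: 27.7 nM
Compound 2 `COc1cc(N(CC2CC2)c2ccc(Cl)c3ccccc23)cnc1C(=O)CCCC(=O)O`: "not determined" (no result reported)
Compound 3 `COc1nc(C(=O)[C@@H]2C[C@H]2C(=O)O)ncc1N(CC1CC1)c1ccc(Cl)c2ccccc12`: "not determined" (no result reported)

In an assay on isolated protein for inhibition of leukotriene C4 synthase (Homo sapiens), read by LC-MS, with stated times of 45 min and 20 min (on this read-out lower numbers stand for stronger inhibition and higher numbers for weaker inhibition), compound 1 gives 27.7 nM and is the only one of the three with a number; for compound 2 and compound 3 no result was reported, so nothing can be said about how they compare. Compound 4 `COc1cc(N(CC2CC2)c2cc(Cl)c(F)cc2F)cnc1C(=O)[C@H]1C[C@@H]1C(=O)O` is not yet measured. It differs from compound 1 in one place: 5-chloro-2,4-difluorophenyl in place of 3,4-dichlorophenyl on a nitrogen on an aromatic ring. Both groups are halogenated rings of the same size with no donors or acceptors, so the change is modest. Going by the values given here, with no measured pair of this kind to lean on, the step from compound 1 to compound 4 is expected to be small, at most a slight weakening, a 1.3-fold higher number from compound 1 to compound 4 (0.10 log units; within the scatter). Compound 4 is therefore estimated at 35 nM, within 12 nM to 100 nM.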

Compound 4, half-maximal inhibitory concentration: 27.6 nM
Compound 4: middle estimate off by 1.3-fold (0.10 log units), on the high side; measured number inside the range.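

On a nitrogen on an aromatic ring, 5-chloro-2,4-difluorophenyl in place of 3,4-dichlorophenyl gives, in this assay, a 1.0-fold lower number from compound 1 to compound 4 (0.00 log units; within the scatter), so the two halogenated rings cannot be told apart at this place. Going by these compounds alone, this is the first comparison with a number at both ends, as compound 2 and compound 3 have no result. No measurement is available to explain this match.
Going by these compounds, whether a plain phenyl ring, or a ring carrying a nitrile or an amine, would perform the same at this place remains open.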